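A chloro group on two related pyridyl vinyl sulfones

The source may report more compounds than this note shows. Statements on the series, on what has been measured and on what is new or still open speak of the compounds shown alone.

The series rests on a small set of vinyl sulfones that carry a pyridine on one side and a fluorophenyl on the other. Compound 1 `O=S(=O)(/C=C/c1ccccn1)c1ccccc1F` and compound 2 `O=S(=O)(/C=C/c1cccc(Cl)n1)c1ccccc1F` share one core; compound 3 `O=S(=O)(/C=C/c1ccccn1)c1ccc(F)cc1` and the still unmeasured compound 4 `O=S(=O)(/C=C/c1ccc(Cl)cn1)c1ccc(F)cc1` share another, and the difference between the two cores is not broken down here.

In an assay on U2OS cells for activation of nuclear factor erythroid 2-related factor 2 (Homo sapiens), read by beta-arrestin recruitment, with a stated time of 6 h (on this read-out lower numbers stand for an effect already at smaller amounts and higher numbers for an effect only at larger amounts of compound), compound 1 gives 1050 nM, while compound 2 gives 898 nM. The step is a 1.2-fold lower number from compound 1 to compound 2 (0.07 log units; within the scatter), which corresponds to chloro in place of hydrogen on an aromatic carbon. Compound 3 gives 3100 nM, the highest of the three numbers; its nearest neighbour is compound 1, and both it and compound 2 lie beyond the scatter from compound 3.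

Compound 4 arises from compound 3 by chloro in place of hydrogen on an aromatic carbon. This is the same kind of change as that from compound 1 to compound 2, but not the same: in the earlier pair the chloro sits next to the ring nitrogen and meta to a large group, whereas here it sits two atoms from the ring nitrogen and para to a large group.

For the measured compounds named here, the step from compound 3 to compound 4 is expected to be about a 1.2-fold lower number from compound 3 to compound 4 (0.08 log units; within the scatter), because the one comparable change gave only a 1.2-fold lower number from compound 1 to compound 2 (0.07 log units; within the scatter), a shift that does not exceed the scatter. On that basis compound 4 is estimated at 2600 nM, most likely falling between 1200 nM and 6000 nM.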

Compound 4, half-maximal effective concentration: 4370 nM
Compound 4: the middle estimate sits 1.7-fold (0.23 log units) below what was measured, within the range that was stated.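

In this assay, chloro in place of hydrogen on an aromatic carbon again leaves the number within the scatter, the new step being a 1.4-fold higher number from compound 3 to compound 4 (0.15 log units; within the scatter). Set side by side, the two steps do not differ, so across these two cores the change carries over as one that produces no shift beyond the scatter: the same change on two cores in this assay, a 1.2-fold lower number (0.07 log units; within the scatter) from compound 1 to compound 2 and a 1.4-fold higher number (0.15 log units; within the scatter) from compound 3 to compound 4, 1.6-fold (0.22 log units) apart, within the scatter of two such steps This does not show that chloro is without effect throughout the series, for the evidence rests on only two pairs, and since the chloro stands at a different place in each pair and the cores differ as well, the influence of place cannot be separated from that of the core.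

The compounds shown leave open whether an amine or a carboxylic acid, set on the ring in place of chloro, would also leave the number within the scatter on either core. They also leave open whether chloro itself would give a step within the scatter at other places on that ring, or whether a larger group such as a longer alkyl chain would do so at the places already occupied.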